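A few compounds are considered here, and "the series" means these few. Any claim that something is new, unique, unknown or untested is made for them only; others in the source may bear on it.

Compound 1 `C[C@H](Nc1nc(N)nc(N)c1C#N)c1cc2ccc(F)cn2c(=O)c1-c1ccccc1` gives 88%.
Compound 2 `C[C@H](Nc1nc(N)ncc1C#N)c1cc2ccc(F)cn2c(=O)c1-c1ccccc1` gives 74%.
Compound 3 `Cc1nc(N)c(C#N)c(N[C@@H](C)c2cc3ccc(F)cn3c(=O)c2-c2ccccc2)n1` gives "not determined" (no result reported), so no result was reported for it.

These numbers come from an ADME assay on microsomes from liver (Rattus norvegicus), read by LC-MS, using NADPH, with a stated time of 30 min, tested at 1 uM; a higher number here means that more of the compound is left, a lower number that less of the compound is left. Compound 1 stands highest of the two numbers available; the nearest is compound 2, and the step of a number 14 percentage points lower from compound 1 to compound 2 (beyond the scatter) goes with the replacement of an amino group on an aromatic carbon by hydrogen. For compound 3 no value was reported in this assay.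

Compound 4 `C[C@H](Nc1nc(N)nc(N)c1C#N)c1c(-c2ccccc2)c(=O)n2cc(F)ccc2c1-c1ccc(C(N)=O)cc1` differs from compound 1 in one place: 4-carbamoylphenyl in place of hydrogen on an aromatic carbon. Within the data shown here, no measured step covers a change of this kind; the single measured step concerns a different position and a different sort of group, so it does not bear on this change. What can be expected for compound 4 therefore rests on the value of compound 1 alone, with a wide uncertainty. The step of a number 8 percentage points lower from compound 1 to compound 4 (within the scatter) is expected to stay within the usual scatter. Compound 4 is thus estimated at 80%, in a range from 55% to 95%.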

Compound 4, percent of the compound remaining: 100%
For compound 4 the middle estimate is 20 percentage points below the measured one; the measured number lies above the stated range.
By their numbers in this assay, from the lowest: compound 2; then compound 1; then compound 4.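

In this assay, among these compounds, the earlier compounds differ only at another place in the molecule, so this is the first reading at this position, on an aromatic carbon two atoms from the ring nitrogen. Putting 4-carbamoylphenyl in place of hydrogen here gives a number 12 percentage points higher from compound 1 to compound 4 (beyond the scatter), which shows that this large group, with its own six-membered aromatic ring, can sit at this position with no loss in the percent of compound remaining. No measurement at hand gives a reason for this rise.

Still open, going by these compounds, is whether the rise goes with the phenyl ring itself or with the carbamoyl group on it; a plain phenyl, a 4-carboxyphenyl or a 4-aminophenyl group at this position would help separate the two. Also open, on these data alone, is whether the same change would give a similar step on compound 2.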